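A few compounds are considered here, and "the series" means these few. Any claim that something is new, unique, unknown or untested is made for them only; others in the source may bear on it.

Measured so far in an assay on HEK293 cells for inhibition of cyclin-dependent kinase 14 (Homo sapiens), with a stated time of 4 h; on this read-out lower numbers stand for stronger inhibition and higher numbers for weaker inhibition:
compound 1 `CCC(=O)Nc1cccc(CN2CCC(NC(=O)c3n[nH]cc3NC(=O)c3c(Cl)cccc3Cl)CC2)c1`: > 1000 nM
compound 2 `CN(C)C/C=C/C(=O)Nc1cccc(S(=O)(=O)N2CCC(NC(=O)c3n[nH]cc3NC(=O)c3c(Cl)cc(Cl)cc3Cl)CC2)c1`: >= 500 nM

Compound 1 sits at a limit of this assay, > 1000 nM, so no number is known for it. Compound 2 likewise sits at a limit, >= 500 nM. For the measured compounds named here, both values of the series are therefore limits, and no step between measured compounds can be stated.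

Compound 3 `CN(C)C/C=C/C(=O)Nc1cccc(CN2CCC(NC(=O)c3n[nH]cc3NC(=O)c3c(Cl)cccc3Cl)CC2)c1` differs from compound 1 in one place: 3-(dimethylamino)prop-1-en-1-yl in place of ethyl on a carbonyl carbon. With compound 1 at a limit, the direction of the step cannot be read from the measured pair; the expected change is an at least 2.5-fold lower number from compound 1 to compound 3 (0.39 log units; beyond the scatter). For compound 3 the estimate in this assay is 400 nM, within 60 nM to 3000 nM, with a fair chance that only a limit is reported again.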

Compound 3, half-maximal inhibitory concentration: 500 nM
Beside the measured number, compound 3's estimate is 1.3-fold (0.10 log units) below it, and the stated range covers the measured number.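

In this assay, 3-(dimethylamino)prop-1-en-1-yl in place of ethyl on a carbonyl carbon gives an at least 2.0-fold lower number from compound 1 to compound 3 (0.30 log units; that floor lies within the scatter). For the compounds shown here, compound 3, at 500 nM, supplies the first value that is a number and not a limit. The full size of the step cannot be read because compound 1 stands at a limit: the limit of > 1000 nM in this assay, at which 1 of the 3 values shown sits.

As far as these compounds go, it remains open whether the dimethylamino group or the double bond accounts for any change. A saturated 3-(dimethylamino)propyl chain or a morpholine in place of dimethylamino at this position would separate the two.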